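The compounds below may be only part of what the source reports. "The series", "measured", "known", "first", "only" and "open" are said of these compounds alone.

In a physicochemical assay for lipophilicity (a higher number here means a more lipophilic compound, a lower number a more polar compound), compound 2 (`C[C@H]1CC[C@@H]2[C@@H](OC(=O)[C@]23CC(c2cccc(Cl)c2)N(c2ccccc2)O3)[C@]2(C)C(=O)C=C[C@@]12O`) gives 3.87 and compound 1 (`Cc1ccc(C2C[C@@]3(ON2c2ccccc2)C(=O)O[C@@H]2[C@H]3CC[C@H](C)[C@]3(O)C=CC(=O)[C@@]23C)cc1`) gives 3.64 so the two lie within the scatter of each other. Compound 3 (`COc1ccc(C2C[C@@]3(ON2c2ccccc2)C(=O)O[C@@H]2[C@H]3CC[C@H](C)[C@]3(O)C=CC(=O)[C@@]23C)cc1Br`) keeps the shared core but carries 3-bromo-4-methoxyphenyl in place of 3-chlorophenyl on a saturated ring carbon. Among the measured compounds shown here, only one measured step bears on this change, the swap of groups at that same carbon (a number 0.23 log units higher from compound 1 to compound 2 (within the scatter)). That step is small, and neither measured compound carries a bromine or a methoxy group, so the evidence is thin. No shift beyond the scatter is therefore expected in this assay and the estimated change is modest, an expected a number 0.08 log units higher from compound 2 to compound 3 (within the scatter) in all. Compound 3 is estimated at 3.95 (expected range 3.5 to 4.4).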

Compound 3, partition coefficient: 3.98
For compound 3 the middle estimate is 0.03 log units below the measured one; measured number inside the range.
By their numbers in this assay, from the lowest: compounds 1, 2 and 3 (each within the scatter of the next, the first and the last beyond it).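

Placing 3-bromo-4-methoxyphenyl in place of 3-chlorophenyl on this saturated ring carbon gives, in this assay, a number 0.11 log units higher from compound 2 to compound 3 (within the scatter) and so leaves these two compounds within the usual scatter of each other, even though the entering group brings a hydrogen-bond acceptor. Set against 4-methylphenyl, the same group gives a number 0.34 log units higher from compound 1 to compound 3 (beyond the scatter) and this is the first step at this carbon to pass beyond the scatter, though only modestly. Nothing measured here accounts for that step.

As far as these compounds go, all three groups at this carbon are substituted phenyl rings, so the effect of an amine, a carboxylic acid or a longer alkyl chain there remains open. The bromine and the methoxy group also enter together, so the share of each in the step from 4-methylphenyl cannot be read separately.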